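This account rests on a few compounds, and the source may have more. Where it says the series, first, only, none or still open, it means among the compounds named here.

Measured so far:
- compound 1 `COC(=O)C1=CO[C@@H](O[C@@H]2O[C@H](CO)[C@@H](OC(C)=O)[C@H](OC(C)=O)[C@H]2OC(C)=O)[C@@H]2[C@@H](C)[C@@H](OC(C)=O)C[C@H]12`: "not active" (no number reported)
- compound 2 `CCC(=O)OC[C@H]1O[C@@H](O[C@@H]2OC=C(C(=O)OC)[C@H]3C[C@H](OC(C)=O)[C@H](C)[C@@H]23)[C@H](OC(C)=O)[C@@H](OC(C)=O)[C@@H]1OC(C)=O`: 0.85 ug/mL
- compound 3 `C=CC(=O)OC[C@H]1O[C@@H](O[C@@H]2OC=C(C(=O)OC)[C@H]3C[C@H](OC(C)=O)[C@H](C)[C@@H]23)[C@H](OC(C)=O)[C@@H](OC(C)=O)[C@@H]1OC(C)=O`: "not active" (no number reported)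

In a functional assay on COLO 320 cells (Homo sapiens) for cytotoxicity, read by MTT assay, with a stated time of 4 h (on this read-out lower numbers stand for stronger inhibition and higher numbers for weaker inhibition), compound 3 gives "not active" (no number reported) and has no number, the same outcome as compound 1. Only compound 2 has a number, at 0.85 ug/mL.

The next structure is compound 4 `COC(=O)C1=CO[C@@H](O[C@@H]2O[C@H](COC(=O)C=C(C)C)[C@@H](OC(C)=O)[C@H](OC(C)=O)[C@H]2OC(C)=O)[C@@H]2[C@@H](C)[C@@H](OC(C)=O)C[C@H]12`, with 2-methylprop-1-en-1-yl in place of vinyl on a carbonyl carbon. Without a number for compound 3, no step size can be stated. A move towards measurable inhibition in this assay is expected, near the level of compound 2 at 0.85 ug/mL, though another result without a number is about equally likely. For compound 4 the estimated value is 2 ug/mL, with an expected range of 0.4 ug/mL to 12 ug/mL.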

Compound 4, half-maximal inhibitory concentration: 0.08 ug/mL
Beside the measured number, compound 4's estimate is 25-fold (1.40 log units) above it, outside the stated range (below it).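

In this assay the group on this carbonyl carbon separates inactive from highly active: compound 3, with vinyl, gives "not active" (no number reported) and so allows no readable step, while 2-methylprop-1-en-1-yl in place of ethyl gives an 11-fold lower number from compound 2 to compound 4 (1.03 log units; beyond the scatter). A double bond alone does not decide the outcome, since vinyl and 2-methylprop-1-en-1-yl each carry one and only compound 4 has a number. Nothing measured here explains the difference.

From the compounds shown here alone, it remains open whether a phenyl or a saturated longer chain such as hexyl on the same carbonyl carbon would reach the level of compound 4.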